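Piperidine in Place of Butyl(methyl)amino on the Shared Core

The source may hold more compounds than are shown below. What is called first, only, known or untested is meant among the compounds shown, and "the series" means these compounds.

Compound 1 `CCCCN(C)c1nc(C(F)(F)F)ccc1CNC(=O)C(C)c1ccc(NS(C)(=O)=O)c(F)c1` gives 21.3 nM in a functional assay on CHO-K1 cells for antagonist activity at transient receptor potential cation channel subfamily V member 1 (Homo sapiens), read by FLIPR (a lower number here means a stronger inhibitor, a higher number a weaker inhibitor), second highest of three numbers. Compound 3 `C[C@H](C(=O)NCc1ccc(C(F)(F)F)nc1N1CCC(c2ccccc2)CC1)c1ccc(NS(C)(=O)=O)c(F)c1` gives 17.4 nM, within the scatter of compound 1, while compound 2 `C[C@@H](C(=O)NCc1ccc(C(F)(F)F)nc1N1CCC(c2ccccc2)CC1)c1ccc(NS(C)(=O)=O)c(F)c1` gives 2350 nM. Going by the values given here, the only measured step is a 140-fold lower number from compound 2 to compound 3 (2.13 log units; beyond the scatter), a change of configuration alone (the fact that compounds 2 and 3 differ only in the configuration as drawn); it does not touch the change now considered. Compound 4 `CC(C(=O)NCc1ccc(C(F)(F)F)nc1N1CCC(CN(C)C)CC1)c1ccc(NS(C)(=O)=O)c(F)c1` differs from compound 1 by 4-((dimethylamino)methyl)piperidin-1-yl in place of butyl(methyl)amino on an aromatic carbon. Among the compounds with values here, compounds 1 and 3 show that a piperidin-1-yl on that aromatic carbon is compatible with a low number, but no measured step covers the 4-((dimethylamino)methyl)piperidin-1-yl itself. Compound 4 is therefore expected to show at most a modest step, a 2.1-fold higher number from compound 1 to compound 4 (0.32 log units; beyond the scatter), estimated at 45 nM with a range of 9 nM to 250 nM.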

Compound 4, half-maximal inhibitory concentration: 426 nM
Compound 4: middle estimate off by 9.5-fold (0.98 log units), on the low side; the measured number lies above the stated range.
By their numbers in this assay, from the lowest: compounds 3 and 1 (each within the scatter of the next); then compound 4; then compound 2.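

On an aromatic carbon next to the ring nitrogen, the 4-((dimethylamino)methyl)piperidin-1-yl group is not tolerated as well as butyl(methyl)amino: this assay gives a 20-fold higher number from compound 1 to compound 4 (1.30 log units; beyond the scatter). A piperidin-1-yl at this position therefore does not by itself ensure a low number, and the substituent on the ring matters. Nothing measured here accounts for this step. On these data alone, it remains open whether the step follows the dimethylamino group or the ring itself. An unsubstituted piperidin-1-yl or a 4-(methoxymethyl)piperidin-1-yl would help separate the two.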